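Series notes: aminopyridazinyl variant of the amide core

A few compounds are considered here, and "the series" means these few. Any claim that something is new, unique, unknown or untested is made for them only; others in the source may bear on it.

For the measured compounds named here, compound 2 `Cc1cc(C)c(-c2ccc(N)cn2)cc1NC(=O)c1ccc(OCc2ccccn2)cc1` is examined in an ADME assay on microsomes from liver (Homo sapiens) for metabolic stability (on this read-out higher numbers stand for fast clearance and lower numbers for slow clearance), where compound 2 gives 9 mL.min-1.g-1, the lowest of the two numbers so far. Going by the values given here, its only neighbour, compound 1 `Cc1cc(C)c(-c2ccccn2)cc1NC(=O)c1ccc(OCc2ccccn2)cc1`, gives 209 mL.min-1.g-1 in this assay, and the step of a 23-fold lower number from compound 1 to compound 2 (1.37 log units; beyond the scatter) is the sole measured comparison. Among the compounds with values here, compound 3 `Cc1cc(C)c(-c2ccc(N)nn2)cc1NC(=O)c1ccc(OCc2ccccn2)cc1` carries a change, (6-aminopyridazin-3-yl in place of 5-aminopyridin-2-yl on an aromatic carbon), that no measured step addresses. The amino group gained in a 23-fold lower number from compound 1 to compound 2 (1.37 log units; beyond the scatter) remains in place, so the step of a 1.1-fold lower number from compound 2 to compound 3 (0.05 log units; within the scatter) is expected to stay within the scatter. Compound 3 is estimated at 8 mL.min-1.g-1, in a range from 3 mL.min-1.g-1 to 22 mL.min-1.g-1.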

Compound 3, intrinsic clearance in microsomes: < 4 mL.min-1.g-1
Compound 3 was reported as a limit; the forecaster's own chance of this, stated with the estimate: 10%; at least 2.0-fold (0.30 log units) between middle value and limit.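

Clearance at this position still responds to the ring once the amino group is present: 6-aminopyridazin-3-yl in place of 5-aminopyridin-2-yl gives an at least 2.2-fold lower number from compound 2 to compound 3 (0.35 log units; beyond the scatter) in this assay and not the flat step the earlier pair left possible. Measured against pyridin-2-yl, the same group gives an at least 52-fold lower number from compound 1 to compound 3 (1.71 log units; beyond the scatter) overall. Compound 3 is a limit of the assay and not a number, so both steps are bounds: the limit of < 4 mL.min-1.g-1 in this assay, at which 1 of the 3 values shown sits.

From the compounds shown here alone, how far compound 3 lies past its limit stays open. Also open, going by these compounds, is whether a hydroxyl or a dimethylamino group in place of the amino group would keep clearance this low on either ring.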